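Ethyl Replaces Chloro on the Anilide of Compound 3

The source may report more compounds than this note shows. Statements on the series, on what has been measured and on what is new or still open speak of the compounds shown alone.

Three compounds have been measured in an assay on isolated protein for inhibition of Carbonyl reductase [NADPH] 1 (Homo sapiens); on this read-out lower numbers stand for stronger inhibition and higher numbers for weaker inhibition:

compound 1 `N=c1oc2c(O)cccc2cc1C(=O)Nc1cccc(F)c1`: 370 nM
compound 2 `N=c1oc2c(O)cccc2cc1C(=O)Nc1ccc(F)cc1`: 440 nM
compound 3 `N=c1oc2c(O)cccc2cc1C(=O)Nc1cccc(Cl)c1`: 120 nM

Compound 3 gives the lowest number of the three in this assay. Its gap to compound 1 is the step of a 3.1-fold lower number from compound 1 to compound 3 (0.49 log units; beyond the scatter), and its gap to compound 2 is the step of a 3.7-fold lower number from compound 2 to compound 3 (0.56 log units; beyond the scatter); both steps lie beyond the scatter. Compound 1 and compound 2 differ only in the step of a 1.2-fold higher number from compound 1 to compound 2 (0.08 log units; within the scatter), which stays within the scatter.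

Compound 4 `CCc1cccc(NC(=O)c2cc3cccc(O)c3oc2=N)c1` is not yet measured. It differs from compound 3 by ethyl in place of chloro on an aromatic carbon. Among the compounds with values here, the only step that touches this position is the one from compound 1 to compound 3, where a halogen was exchanged for a larger halogen and the number fell. Within the data shown here, no measured pair exchanges a halogen for an alkyl group, so the direction is uncertain. The expectation for compound 4 is therefore a step of a 1.3-fold higher number from compound 3 to compound 4 (0.12 log units; within the scatter), not beyond the scatter. Compound 4 is estimated at 160 nM in this assay, within the range 55 nM to 480 nM.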

Compound 4, half-maximal inhibitory concentration: 250 nM
Compound 4: the middle estimate sits 1.6-fold (0.19 log units) below what was measured, and the stated range covers the measured number.
By their numbers in this assay, from the lowest: compound 3; then compounds 4, 1 and 2 (each within the scatter of the next).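

In this assay, putting ethyl in place of chloro on this aromatic carbon, meta to a large group, gives a 2.1-fold higher number from compound 3 to compound 4 (0.32 log units; beyond the scatter), so this alkyl group does not hold the level reached with chloro. Set against the fluoro analogue, the same group gives a 1.5-fold lower number from compound 1 to compound 4 (0.17 log units; within the scatter), which leaves ethyl and fluoro inseparable here and chloro alone apart from the other two groups at this position. Nothing available explains why chloro and ethyl differ in this way.

The compounds shown leave open whether bromo, methyl or trifluoromethyl at this position would fall nearer to chloro or to ethyl. They also leave open how a longer chain, a methoxy group or an amine would behave there.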